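From an Isobutyl to a Chloro Group

The source may hold more compounds than are shown below. What is called first, only, known or untested is meant among the compounds shown, and "the series" means these compounds.

Three sulfonamides sharing one core have been measured in a functional assay on M21 cells (Homo sapiens) for antiproliferative activity, read by sulforhodamine B assay, with a stated time of 48 h; a higher number here means a weaker inhibitor, a lower number a stronger inhibitor. Compound 1 `CCCCOc1ccc(NS(=O)(=O)c2ccc(N3CCNC3=O)cc2)cc1` gives 580 nM. Compound 3 `COc1cccc(NS(=O)(=O)c2ccc(N3CCNC3=O)cc2)c1` gives 65 nM. For the measured compounds named here, compound 2 `CC(C)Cc1ccc(NS(=O)(=O)c2ccc(N3CCNC3=O)cc2)cc1` carries an isobutyl group in place of the butoxy group of compound 1, and the step of an at least 1.7-fold higher number from compound 1 to compound 2 (0.23 log units; that floor lies within the scatter) is the only single-point change measured here. Going by the values given here, for compound 2 the reading > 1000 nM is a limit of the assay, not a number, and this is the one reading among three that sits at the limit of > 1000 nM in this assay, at which 1 of the 3 values shown sits.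

Compound 4 `O=C1NCCN1c1ccc(S(=O)(=O)Nc2ccc(Cl)cc2)cc1` is the unmeasured partner of compound 2: chloro in place of isobutyl on an aromatic carbon. Among the compounds with values here, no measured step exchanges isobutyl for chloro, so the expectation rests on compound 1 at 580 nM and on the reading of compound 2. With a group closer in size to butoxy than to isobutyl, compound 4 is expected to fall somewhat below the limit, an estimated step of an at least 2.0-fold lower number from compound 2 to compound 4 (0.30 log units; that floor lies within the scatter). Compound 4 is therefore estimated at about 500 nM, between 120 nM and 3000 nM.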

Compound 4, half-maximal inhibitory concentration: 90 nM
For compound 4 the middle estimate is 5.6-fold (0.74 log units) above the measured one; the measured number lies below the stated range.
By their numbers in this assay, from the lowest: compounds 3 and 4 (each within the scatter of the next); then compound 1. At a limit, above all of these: compound 2.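

The reading for compound 2 is a limit of the assay, not a number: the limit of > 1000 nM in this assay, at which 1 of the 4 values shown sits. Even so, in this assay the aromatic carbon para to a large group clearly responds to what it carries: chloro in place of isobutyl gives an at least 11-fold lower number from compound 2 to compound 4 (1.04 log units; beyond the scatter), and chloro in place of butoxy gives a 6.4-fold lower number from compound 1 to compound 4 (0.81 log units; beyond the scatter). A chloro at this position also brings the series level with the 3-methoxyphenyl of compound 3, with a 1.4-fold higher number from compound 3 to compound 4 (0.14 log units; within the scatter), so these two cannot be told apart.

From the compounds shown here alone, whether the single atom or chlorine itself matters stays open, and a methyl or a bromo on the same carbon would bear on that. Also open, going by these compounds, is whether an amine or a carboxylic acid at this position would give a similar number.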